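From compound 3 to compound 4: a hydroxyphenyl swap

The source may report more compounds than this note shows. Statements on the series, on what has been measured and on what is new or still open speak of the compounds shown alone.

Compound 1 `Oc1cccc(-c2cc(-c3ccc(F)cc3)cc(-c3cccc(O)c3)n2)c1` gives 6310 nM in a functional assay on HCT-15 cells (Homo sapiens) for inhibition; on this read-out higher numbers stand for weaker inhibition and lower numbers for stronger inhibition.
Compound 2 `Oc1ccc(-c2cc(-c3ccc(F)cc3)cc(-c3cccc(O)c3)n2)cc1` gives 5020 nM in this assay.
Compound 3 `Oc1cccc(-c2cc(-c3ccccc3OC(F)(F)F)cc(-c3cccc(O)c3)n2)c1` gives 4220 nM in this assay.
Compound 4 `Oc1ccc(-c2cc(-c3ccccc3OC(F)(F)F)cc(-c3cccc(O)c3)n2)cc1` is not yet measured in this assay.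

Compounds 1 and 2 share one core, compounds 3 and 4 another; the difference between the two cores is not broken down here. From compound 1 to compound 2 the change is 4-hydroxyphenyl in place of 3-hydroxyphenyl on an aromatic carbon, and it made the step of a 1.3-fold lower number from compound 1 to compound 2 (0.10 log units; within the scatter). From compound 3 to compound 4 the change is 4-hydroxyphenyl in place of 3-hydroxyphenyl on an aromatic carbon, the same kind of change: in compound 1 the place is meta to a 4-fluorophenyl group, in compound 3 it is meta to a large group. Compound 3 stands within the scatter of both compound 1 and compound 2. Because a 1.3-fold lower number from compound 1 to compound 2 (0.10 log units; within the scatter) lies within the scatter, a step of similar size, a 1.2-fold lower number from compound 3 to compound 4 (0.08 log units; within the scatter), is expected. Compound 4 is expected to give 3500 nM, between 1500 nM and 8000 nM.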

Compound 4, half-maximal inhibitory concentration: 2310 nM
Beside the measured number, compound 4's estimate is 1.5-fold (0.18 log units) above it; the measured number falls inside the stated range.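

In this assay, putting 4-hydroxyphenyl in place of 3-hydroxyphenyl gave a 1.8-fold lower number from compound 3 to compound 4 (0.26 log units; within the scatter). Set beside the earlier step, the swap cannot be told apart on the two cores: the same change on two cores in this assay, a 1.3-fold lower number (0.10 log units; within the scatter) from compound 1 to compound 2 and a 1.8-fold lower number (0.26 log units; within the scatter) from compound 3 to compound 4, 1.5-fold (0.16 log units) apart, within the scatter of two such steps. This shows that the swap carries over from one core to the other without a detectable difference, but neither step stands beyond the scatter, and two pairs of compounds cannot show how it would behave on any further core.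

The compounds shown leave open whether an amine or a carboxylic acid in place of the hydroxyl would shift the number beyond the scatter. They also leave open what the same swap would do at the remaining 3-hydroxyphenyl group.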